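Methylamino in place of chloro on the shared core

The source may hold more compounds than are shown below. What is called first, only, known or untested is meant among the compounds shown, and "the series" means these compounds.

Three compounds carry iodo, bromo or chloro on the same aromatic carbon of the shared core. In an ADME assay on L1210/0 cells (Mus musculus) for cytotoxicity, with a stated time of 48 h (a lower number here means a stronger inhibitor, a higher number a weaker inhibitor), compound 1 (`Nc1nc2c(nc(I)n2COCCO)c(=O)[nH]1`) gives 111000 nM. Compound 2 (`Nc1nc2c(nc(Br)n2COCCO)c(=O)[nH]1`) reports only a limit, > 200000 nM. Compound 3 (`Nc1nc2c(nc(Cl)n2COCCO)c(=O)[nH]1`) also reports only a limit, > 200000 nM. Compound 3 thus has no number of its own and stands at the limit of > 200000 nM in this assay, at which 2 of the 3 values shown sit.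

Compound 4 (`CNc1nc2c(=O)[nH]c(N)nc2n1COCCO`) carries methylamino in place of chloro on an aromatic carbon, between two ring nitrogen atoms (methylamino in place of chloro on an aromatic carbon).

The measured steps at this carbon are exchanges among the three halogens. They are an at least 1.8-fold higher number from compound 1 to compound 2 (0.25 log units; that floor lies within the scatter) and an at least 1.8-fold higher number from compound 1 to compound 3 (0.25 log units; that floor lies within the scatter), and neither shows a change beyond the scatter. The third, a step that the two limits leave unreadable from compound 2 to compound 3, gives no size. Among the compounds with values here, no measured compound has a nitrogen substituent at this carbon, so the evidence for the new group is thin. No step beyond the scatter is therefore expected in this assay, and a further report of only a limit is quite likely. The expected step is a number no higher from compound 3 to compound 4 (the limit leaves the size open). For compound 4 the estimate is 200000 nM, with an expected range of 90000 nM to 400000 nM.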

Compound 4, half-maximal inhibitory concentration: > 200000 nM
Compound 4: only a limit was reported (the forecaster's own chance of this, stated with the estimate: 65%); the middle value sits exactly at the limit.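

Methylamino is the first nitrogen substituent seen at this carbon, and compound 4 in this assay gives only a limit, so a halogen is not needed at this position for the read-out to stay at a limit. Within the data shown here, compound 1 remains the only compound with a number of its own, and the one readable step is an at least 1.8-fold higher number from compound 1 to compound 4 (0.25 log units; that floor lies within the scatter); the steps to compound 4 from compound 2 and from compound 3 cannot be read, as both ends of each are limits. Replacing chloro with methylamino therefore adds a nitrogen substituent without moving the series off its common ceiling: the limit of > 200000 nM in this assay, at which 3 of the 4 values shown sit.

Going by these compounds, how far compound 2, compound 3 and compound 4 lie past that limit remains unknown, so it is open whether methylamino differs from bromo or chloro here at all. On these data alone, it is also open whether a plain amino group, a dimethylamino group or a longer alkylamino chain on this carbon would give a number within the range of this assay.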